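The source may hold more compounds than are shown below. What is called first, only, known or untested is meant among the compounds shown, and "the series" means these compounds.

Compound 1 `C=C1CCC[C@]2(C)CCC(c3cn(-c4cccc([N+](=O)[O-])c4)nn3)=CC[C@@]12C`: 62500 nM
Compound 2 `C=C1CCC[C@]2(C)CCC(c3cn(-c4ccccc4C(C)=O)nn3)=CC[C@@]12C`: 48500 nM

Both compounds were tested in a functional assay on DU-145 cells (Homo sapiens) for cytotoxicity, read by MTT assay, with a stated time of 48 h; a higher number here means a weaker inhibitor, a lower number a stronger inhibitor. Only these two numbers exist so far, and compound 2, at 48500 nM, cannot be told apart from compound 1, because a 1.3-fold lower number from compound 1 to compound 2 (0.11 log units; within the scatter) is a gap no larger than repeat measurements can produce by themselves.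

Compound 3 `C=C1CCC[C@]2(C)CCC(c3cn(-c4ccc(C)cc4)nn3)=CC[C@@]12C` keeps the shared core and carries 4-methylphenyl in place of 2-acetylphenyl on an aromatic nitrogen. Going by the values given here, one measured step bears on this change, the swap of 3-nitrophenyl for 2-acetylphenyl at that same nitrogen, and it stayed within the scatter. Among the compounds with values here, that is thin evidence, since no measured compound carries 4-methylphenyl. Even so, no step beyond the scatter is expected in this assay. The expected change is a 1.0-fold higher number from compound 2 to compound 3 (0.01 log units; within the scatter). Compound 3 is estimated at 50000 nM, with an expected range of 22000 nM to 110000 nM.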

Compound 3, half-maximal inhibitory concentration: 132000 nM
Estimate against measurement, compound 3: 2.6-fold (0.42 log units) below; measured number above the stated range.
By their numbers in this assay, from the lowest: compounds 2 and 1 (each within the scatter of the next); then compound 3.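

Putting 4-methylphenyl on this aromatic nitrogen brings a 2.7-fold higher number from compound 2 to compound 3 (0.43 log units; beyond the scatter) and also a 2.1-fold higher number from compound 1 to compound 3 (0.32 log units; beyond the scatter) in this assay and so, unlike the swap between the two earlier groups, moves the number beyond the scatter. The group at this position can therefore change the result, although both steps are modest and compound 3 is the weakest of the three. Of the three groups, only 4-methylphenyl has carbon as its sole heavy atom, but nothing available accounts for the shift.

From the compounds shown here alone, whether a phenyl ring carrying an amine or a carboxylic acid on this nitrogen would raise or lower the number remains open. So does whether any group here could bring the number far below those seen so far.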